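The compounds below may be only part of what the source reports. "The series", "measured", "known", "first", "only" and "open" are said of these compounds alone.

In a functional assay on HepG2 cells (Homo sapiens) for antiproliferative activity, read by CCK-8 assay, with a stated time of 72 h, tested at 2 uM (on this read-out higher numbers stand for a stronger effect at the one concentration tested and lower numbers for a weaker effect), compound 3 `Nc1ccccc1NC(=O)c1ccc(Cn2cnc3c(Nc4ccccc4)nc(Cl)nc32)cc1` gives 49.6%, the highest of the three numbers recorded. Compound 2 `Nc1ccccc1NC(=O)/C=C/c1ccc(Cn2cnc3c(Nc4cccc(Cl)c4)nc(Cl)nc32)cc1` gives 35.8%, a reading below that of compound 3 by more than the usual scatter, and compound 1 `CC(C)n1cnc2c(Nc3cccc(Cl)c3)nc(NCOCc3ccc(C(=O)Nc4ccccc4N)cc3)nc21` gives 1.48%, the lowest of the set by a wide margin. Compound 4 `CC1CCN(c2nc(Cl)nc3c2ncn3Cc2ccc(C(=O)Nc3ccccc3N)cc2)CC1` has not yet been tested in this assay. It differs from compound 3 in one place: 4-methylpiperidin-1-yl in place of anilino on an aromatic carbon. For the measured compounds named here, no measured pair isolates this change, so the expectation rests on compound 3 and its value of 49.6%. The step of a number 14.6 percentage points lower from compound 3 to compound 4 (beyond the scatter) is expected to be a moderate decrease, though it may fall within the scatter. Compound 4 is accordingly estimated at 35%, with a range from 12% to 58%.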

Compound 4, a percentage reported as inhibition, at one concentration (the size of the read-out at that concentration, not a potency): 1.22%
The estimate for compound 4 lay 33.8 percentage points above the measured number, outside the stated range (below it).
By their numbers in this assay, from the lowest: compounds 4 and 1 (each within the scatter of the next); then compound 2; then compound 3.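

Replacing anilino with 4-methylpiperidin-1-yl on the aromatic carbon next to the ring nitrogen gives a number 48.4 percentage points lower from compound 3 to compound 4 (beyond the scatter) in this assay, so the reading at this position depends strongly on the group placed there. The step swaps an aromatic carbon ring with a hydrogen-bond donor for a non-aromatic ring without one, and this single pair cannot separate those two differences. Nothing measured here explains the drop. Going by these compounds, whether an N-methylanilino group, which has an aromatic ring but no amine hydrogen, or a cyclohexylamino group, which keeps that hydrogen on a non-aromatic ring, would restore the reading remains open.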